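The source may hold more compounds than are shown below. What is called first, only, known or untested is meant among the compounds shown, and "the series" means these compounds.

Measured so far in a functional assay on PC-12 cells (Rattus norvegicus) for cytotoxicity, read by MTT assay, with stated times of 2 h and 24 h, tested at 5 uM; on this read-out higher numbers stand for a stronger effect at the one concentration tested and lower numbers for a weaker effect:
compound 1 `CC(C)c1ccc(-n2nc(-c3ccc(C(F)(F)F)cc3O)nc2-c2ccccc2O)cc1` — compound 1 gives 100%
compound 2 `Oc1cc(C(F)(F)F)ccc1-c1nc(-c2ccccc2O)n(-c2ccc(OC(F)(F)F)cc2)n1` — compound 2 gives 84.9%

Compound 2 stands lowest of the two numbers in this assay. Going by the values given here, the only measured step is a number 15.1 percentage points lower from compound 1 to compound 2 (beyond the scatter). Compound 3 `N#Cc1ccc(-n2nc(-c3ccc(C(F)(F)F)cc3O)nc2-c2ccccc2O)cc1` differs from compound 2 by cyano in place of trifluoromethoxy on an aromatic carbon. Among the compounds with values here, no measured step swaps trifluoromethoxy for cyano, so the step from compound 1 to compound 2 is only a loose guide, showing that a change on the same aromatic carbon can move the read-out modestly. A step of a number 2.9 percentage points lower from compound 2 to compound 3 (within the scatter) is expected, within the scatter. Compound 3 is therefore estimated at 82%, between 60% and 100%.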

Compound 3, a percentage reported as activity, at one concentration (the size of the read-out at that concentration, not a potency): 86.8%
For compound 3 the middle estimate is 4.8 percentage points below the measured one; the range from low to high includes it.
By their numbers in this assay, from the lowest: compounds 2 and 3 (each within the scatter of the next); then compound 1.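

In this assay, cyano in place of trifluoromethoxy on this aromatic carbon gives a number 1.9 percentage points higher from compound 2 to compound 3 (within the scatter), so a group with fewer heavy atoms leaves the read-out unchanged within the scatter. Cyano in place of isopropyl gives a number 13.2 percentage points lower from compound 1 to compound 3 (beyond the scatter), so both replacements of isopropyl shown now read beyond the scatter from it. Nothing measured here explains these numbers.

As far as these compounds go, it remains open whether an amine or a carboxylic acid at this position would read like compound 2 and compound 3 or like compound 1. From the compounds shown here alone, a longer alkyl chain in place of isopropyl is equally open.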